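This account rests on a few compounds, and the source may have more. Where it says the series, first, only, none or still open, it means among the compounds named here.

Compound 3, `CC(C)c1cccc(NC(=O)N[C@@H](C)c2ccccc2)c1`, stands second highest of the three measured in an ADME assay on the whole organism with Oryza sativa as the target, tested at 10 uM (on this read-out higher numbers stand for a weaker effect at the one concentration tested and lower numbers for a stronger effect), where compound 3 gives 86%. Compound 1, `Cc1cccc(NC(=O)N[C@@H](C)c2ccccc2)c1`, gives 100%, and compound 2, `CC(C)c1cccc(NC(=O)N[C@H](C)c2ccccc2)c1`, gives 44%. The step of a number 14 percentage points lower from compound 1 to compound 3 (beyond the scatter) came with isopropyl in place of methyl on an aromatic carbon. The large step of a number 42 percentage points higher from compound 2 to compound 3 (beyond the scatter) arose because of the fact that compounds 2 and 3 differ only in the configuration as drawn. Compound 4, `C[C@H](NC(=O)Nc1cccc(C(F)(F)F)c1)c1ccccc1`, differs from compound 3 by trifluoromethyl in place of isopropyl on an aromatic carbon. Among the measured compounds shown here, only the step from compound 1 to compound 3 bears on this, since it also swaps a group on the same aromatic carbon, and that step was modest. A modest step in this assay, likely downward, is therefore expected. Compound 4 is estimated to give 78%, between 55% and 100%, an expected step of a number 8 percentage points lower from compound 3 to compound 4 (within the scatter).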

Compound 4, a percentage reported as activity, at one concentration (the size of the read-out at that concentration, not a potency): 92%
Compound 4: middle estimate off by 14 percentage points, on the low side; the measured number falls inside the stated range.
By their numbers in this assay, from the lowest: compound 2; then compounds 3, 4 and 1 (each within the scatter of the next, the first and the last beyond it).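

On this aromatic carbon, trifluoromethyl in place of isopropyl gives only a small shift (a number 6 percentage points higher from compound 3 to compound 4 (within the scatter)), and trifluoromethyl in place of methyl gives a similar one (a number 8 percentage points lower from compound 1 to compound 4 (within the scatter)). In this assay, then, a group carrying fluorine fits at this position with no change that stands clear of the scatter from either compound. Nothing at hand offers a reason for this result.

Still open, from the compounds shown here alone, is whether an amine or a carboxylic acid on this carbon would move the number further. Also open, going by these compounds, is whether trifluoromethyl would give a similar number with the configuration drawn in compound 2.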